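Swapping a Hydroxy for a Chloro on the Ketone Ring

This account rests on a few compounds, and the source may have more. Where it says the series, first, only, none or still open, it means among the compounds named here.

Compound 1 `COc1ccc(C(=O)/C=C/c2cc3ccccc3[nH]c2=O)cc1` and compound 2 `O=C(/C=C/c1cc2ccccc2[nH]c1=O)c1ccc(O)cc1` share one core and differ at a single oxygen. In a functional assay on BT-549 cells (Homo sapiens) for cytotoxicity, read by sulforhodamine B assay, with a stated time of 24 h (on this read-out higher numbers stand for weaker inhibition of growth and lower numbers for stronger inhibition of growth), compound 1 gives 7900 nM, and compound 2 gives 5350 nM. The one change between them, hydrogen in place of methyl on an oxygen on an aromatic ring, moves the number by a 1.5-fold lower number from compound 1 to compound 2 (0.17 log units; within the scatter), so compound 2 and compound 1 cannot be told apart on the numbers shown.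

Compound 3 `O=C(/C=C/c1cc2ccccc2[nH]c1=O)c1ccc(Cl)cc1` takes the next step from compound 2: chloro in place of hydroxy on an aromatic carbon of a six-membered aromatic ring of carbon only, para to a large group. Among the measured compounds shown here, no measured step exchanges hydroxy for chloro; the only step at hand, from compound 1 to compound 2, touches the same carbon and stays within the scatter. With nothing pointing to sensitivity at this position, the expected step is a 1.1-fold lower number from compound 2 to compound 3 (0.03 log units; within the scatter) in this assay, no larger than the scatter and without a settled direction. Compound 3 is therefore estimated at 5000 nM, within a range from 1500 nM to 16000 nM.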

Compound 3, concentration for total growth inhibition: 17100 nM
For compound 3 the middle estimate is 3.4-fold (0.53 log units) below the measured one; measured number outside the range, above it.
By their numbers in this assay, from the lowest: compounds 2 and 1 (each within the scatter of the next); then compound 3.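

In this assay this carbon no longer looks indifferent to what it carries: a 3.2-fold higher number from compound 2 to compound 3 (0.50 log units; beyond the scatter) and a 2.2-fold higher number from compound 1 to compound 3 (0.34 log units; beyond the scatter) both point toward weaker inhibition of growth, so compound 3 is the weakest of the three. The earlier pair showed only that hydroxy and methoxy could not be told apart, which might have meant that any small group would be tolerated here; chloro shows that this is not so, though both steps are modest in size. Nothing available explains why chloro behaves differently from the two oxygen-linked groups.

Among the compounds shown here, with only three compounds, it remains open whether the drop belongs to chloro alone or would also appear with other groups on this carbon, such as fluoro, methyl, an amine or a carboxylic acid. Since all three compounds differ only at this one carbon, they also leave open whether the same swap would have a similar effect at another carbon of the ring, or whether a larger group such as a longer alkoxy chain would fall closer to methoxy or to chloro.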